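The source may hold more compounds than are shown below. What is called first, only, known or untested is meant among the compounds shown, and "the series" means these compounds.

Series record in a functional assay on COLO 205 cells (Homo sapiens) for cytotoxicity, read by MTT assay, with a stated time of 48 h; on this read-out higher numbers stand for weaker inhibition and lower numbers for stronger inhibition

- compound 1 `Fc1ccc(Nc2nc(-c3cccc(F)c3)nc3ccc(F)cc23)cc1`: > 50000 nM, a limit of the assay
- compound 2 `Fc1cccc(Nc2nc(-c3cccc(F)c3)nc3ccc(F)cc23)c1`: > 50000 nM, a limit of the assay
- compound 3 `Nc1cccc(Nc2nc(-c3cccc(F)c3)nc3ccc(F)cc23)c1`: not yet measured

Compound 2 stands at the limit of this assay, and no number is known for it. Compound 1 sits at the same limit, so the step that the two limits leave unreadable from compound 1 to compound 2 cannot be read. For the measured compounds named here, the only evidence across the two measured compounds is the limit of > 50000 nM in this assay, at which 2 of the 2 values shown sit; it gives no direction and no size for any change at the nitrogen-borne phenyl ring.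

Compound 3 differs from compound 2 in one place: amino in place of fluoro on an aromatic carbon. The fluoro leaves and an amino enters, bringing one hydrogen-bond donor and one hydrogen-bond acceptor to the same aromatic carbon of the six-membered aromatic ring of carbon only. Going by the values given here, no measured step bears on this change, since the 4-fluorophenyl to 3-fluorophenyl move is itself unreadable. With both anchors at the limit, a return to a measurable number would need a step beyond the scatter in the stronger direction, for which the data give no basis.

The expected step that the limit leaves unreadable from compound 2 to compound 3 is therefore set near zero, with compound 3 most likely also reported as a limit. Compound 3 is estimated at 60000 nM, with a range from 15000 nM to 250000 nM.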

Compound 3, half-maximal inhibitory concentration: > 50000 nM
Compound 3 was reported as a limit (the forecaster's own chance of this, stated with the estimate: 70%); the middle value does not contradict the limit.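

In this assay compound 3 gives > 50000 nM, a limit of the assay. No step among compound 1, compound 2 and compound 3 can be read: the limit of > 50000 nM in this assay, at which 3 of the 3 values shown sit.

The compounds shown leave open whether any change at the nitrogen-borne phenyl ring can bring a measurable value in this assay.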